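Swapping the Amide Cap on a Weak Antiproliferative

The compounds below may be only part of what the source reports. "The series", "measured", "known", "first", "only" and "open" are said of these compounds alone.

Measured compounds:
compound 1 `Cn1ccnc1NC(=O)c1cccc(Nc2ncc(F)c(Nc3ccc(F)cc3)n2)c1`: 15100 nM
compound 2 `CN(C)CC(=O)Nc1cccc(Nc2ncc(F)c(Nc3ccc(F)cc3)n2)c1`: 1210 nM
compound 3 `COc1ccc(N2CCN(C)CC2)cc1Nc1ncc(F)c(Nc2ccc(F)cc2)n1`: 910 nM

For the measured compounds named here, in a functional assay on DU-145 cells (Homo sapiens) for antiproliferative activity, read by sulforhodamine B assay, with a stated time of 3 days (a lower number here means a stronger inhibitor of growth, a higher number a weaker inhibitor of growth), compound 1 gives 15100 nM, the highest of the three numbers; compound 2 and compound 3 both sit well below it, and the only single-point step, a 12-fold lower number from compound 1 to compound 2 (1.10 log units; beyond the scatter), shows that reworking the amide region of compound 1 can move the number strongly. Compound 4 `O=C(Nc1ccc(C(F)(F)F)cc1)c1cccc(Nc2ncc(F)c(Nc3ccc(F)cc3)n2)c1` keeps the shared core and alters only that region: 4-(trifluoromethyl)phenyl in place of 1-methyl-1H-imidazol-2-yl on an amide-type nitrogen. Going by the values given here, no measured step makes this particular exchange, so the direction rests on the loose hint from compound 2 alone. Compound 4 is therefore expected to show a modest improvement, a 3.0-fold lower number from compound 1 to compound 4 (0.48 log units; beyond the scatter), with an estimate of 5000 nM and a range from 1500 nM to 20000 nM.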

Compound 4, concentration for 50% growth inhibition: > 10000 nM
Compound 4 was reported as a limit; the forecaster's own chance of this, stated with the estimate: 5%; middle value at least 2.0-fold (0.30 log units) away from the limit.
By their numbers in this assay, from the lowest: compounds 3 and 2 (each within the scatter of the next); then compound 1.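

Compound 4 gives > 10000 nM, which is a limit and not a number. For the compounds shown here, no step from compound 1 to compound 4 can be read. Going by these compounds, whether 4-(trifluoromethyl)phenyl in place of 1-methyl-1H-imidazol-2-yl raises or lowers the number stays open.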